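This account rests on a few compounds, and the source may have more. Where it says the series, first, only, none or still open, it means among the compounds named here.

Measured so far:
compound 1 `O=C(Nc1cccc(-c2cccc(F)c2)c1)C(Cl)Cl`: > 50000 nM
compound 2 `O=C(Nc1cccc(-c2cccs2)c1)C(Cl)Cl`: > 50000 nM
compound 3 `CC(C)c1ccc(-c2cc(NC(=O)C(Cl)Cl)cc(-c3ccc(C(C)C)cc3)c2)cc1`: > 30000 nM

All three compounds were tested in a functional assay on KB 3-1 cells (Homo sapiens) for cytotoxicity, read by MTT assay, with a stated time of 68 h (on this read-out higher numbers stand for weaker inhibition and lower numbers for stronger inhibition), and none of them returned a number. Going by these compounds, compound 1 stands at a limit of the assay, > 50000 nM, so its true potency remains unknown. Compound 2 also reaches only a limit, > 50000 nM. Compound 3 likewise reaches only a limit, > 30000 nM. Across the set, the results fall into two groups: the limit of > 50000 nM in this assay, at which 2 of the 3 values shown sit, and (the limit of > 30000 nM in this assay, at which 1 of the 3 values shown sits).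

Compound 4 `O=C(Nc1cccc(-c2cccc(C(F)(F)F)c2)c1)C(Cl)Cl` has not yet been measured in this assay. It carries trifluoromethyl in place of fluoro on an aromatic carbon, meta to a large group, while the rest of the core of compound 1 stays the same: trifluoromethyl in place of fluoro on an aromatic carbon. Among the compounds with values here, no measured pair in the set shows what a single change does here, so the size of this step has no direct precedent. The expectation therefore rests on compound 1, whose limit is > 50000 nM. No change beyond the usual scatter is expected, and the estimated step is a number no higher from compound 1 to compound 4 (the limit leaves the size open). A further limit rather than a number is the likeliest report. For compound 4 the expected value is 50000 nM, within an estimated range of 20000 nM to 100000 nM.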

Compound 4, half-maximal inhibitory concentration: > 50000 nM
Compound 4 was reported as a limit; the forecaster's own chance of this, stated with the estimate: 80%; the middle value sits exactly at the limit.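

In this assay compound 4 is reported only as a limit, > 50000 nM, and compound 1 likewise gives only a limit, so the step between compound 1 and compound 4 cannot be read. The compounds shown leave open how potent any of them truly is, and whether trifluoromethyl in place of fluoro changes that potency at all.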